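Diaryl ether ureas: chloro to ethoxy on the carboxyphenyl

This account rests on a few compounds, and the source may have more. Where it says the series, first, only, none or still open, it means among the compounds named here.

Measured compounds:
Compound 1, `CC(C)(C)c1ccccc1Oc1ccc(-c2cccc(C(=O)O)c2)cc1NC(=O)Nc1ccc(OC(F)F)cc1`: in an assay on HeLa cells for inhibition of Indoleamine 2,3-dioxygenase 1 (Homo sapiens), with a stated time of 20 h (a lower number here means a stronger inhibitor, a higher number a weaker inhibitor), compound 1 gives 2600 nM.
Compound 2, `Cc1ccc(NC(=O)Nc2cc(-c3ccc(Cl)c(C(=O)O)c3)ccc2Oc2ccccc2C(C)(C)C)cc1`: in this assay compound 2 gives 2400 nM.

Compound 2 and compound 1 sit at about the same number; the gap between them is within the scatter, so neither is called stronger. Compound 3, `CCOc1ccc(-c2ccc(Oc3ccccc3C(C)(C)C)c(NC(=O)Nc3ccc(C)cc3)c2)cc1C(=O)O`, differs from compound 2 by ethoxy in place of chloro on an aromatic carbon, ortho to a carboxy group. Within the data shown here, no measured pair carries this change, so its size is unknown. The step is expected to be a 1.3-fold higher number from compound 2 to compound 3 (0.10 log units; within the scatter), small, not clearly beyond the scatter. Compound 3 is estimated at 3000 nM, range 1000 nM to 9000 nM.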

Compound 3, half-maximal inhibitory concentration: 120 nM
For compound 3 the middle estimate is 25-fold (1.40 log units) above the measured one, and the stated range ends above it.
By their numbers in this assay, from the lowest: compound 3; then compounds 2 and 1 (each within the scatter of the next).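

This position, ortho to a carboxy group, is sensitive to its substituent: in this assay, ethoxy in place of chloro gives a 20-fold lower number from compound 2 to compound 3 (1.30 log units; beyond the scatter). Compound 1 and compound 2 differ in more than one place and gave no reading of this change, so the effect rests on this single pair. Nothing at hand explains the size of the step.

As far as these compounds go, whether methoxy, a longer chain such as propoxy, or an amine at this position would keep the lower number remains open. Also open, from the compounds shown here alone, is whether ethoxy gives a similar step on the core of compound 1.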